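Phenyl on the Ring Nitrogen: From Compound 2 to Compound 4

This account rests on a few compounds, and the source may have more. Where it says the series, first, only, none or still open, it means among the compounds named here.

Compound 2 `Cc1ccc(C2=NNC(c3cn(-c4ccccc4)nc3-c3ccc(Cl)c(Cl)c3)C2)cc1` stands second of three measured compounds in a functional assay on the whole organism (strain Wistar) for inhibition, with Rattus norvegicus as the target, read by paw edema, with stated times of 30 min and 120 min, at a dose of 50 mg/kg by the oral route (on this read-out lower numbers stand for less inhibition and higher numbers for more inhibition at the one dose given (going by the name of the read-out)), giving 48.4%. Compound 3 `Fc1ccc(C2=NNC(c3cn(-c4ccccc4)nc3-c3ccc(Cl)c(Cl)c3)C2)cc1` gives 46.1%, and the step of a number 2.3 percentage points lower from compound 2 to compound 3 (within the scatter) lies within the scatter. Within the data shown here, compound 1 `Fc1ccc(C2=NN(c3ccccc3)C(c3cn(-c4ccccc4)nc3-c3ccc(Cl)c(Cl)c3)C2)cc1` gives 60.2%, and the step of a number 14.1 percentage points lower from compound 1 to compound 3 (beyond the scatter) is the one measured step at an amine nitrogen in a ring. Compound 4 `Cc1ccc(C2=NN(c3ccccc3)C(c3cn(-c4ccccc4)nc3-c3ccc(Cl)c(Cl)c3)C2)cc1` differs from compound 2 by phenyl in place of hydrogen on an amine nitrogen in a ring. This is the reverse of the change from compound 1 to compound 3, so a rise of about the same size is expected in this assay. For compound 4 the expected step is a number 13.6 percentage points higher from compound 2 to compound 4 (beyond the scatter). Compound 4 is therefore estimated at 62%, with a range from 50% to 74%.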

Compound 4, a percentage reported as inhibition, in the whole organism at one dose (the size of the read-out at that dose, not a potency): 62.5%
The estimate for compound 4 lay 0.5 percentage points below the measured number, within the range that was stated.
By their numbers in this assay, from the lowest: compounds 3 and 2 (each within the scatter of the next); then compounds 1 and 4 (each within the scatter of the next).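

In this assay, phenyl in place of hydrogen on the amine nitrogen in a ring gives a number 14.1 percentage points higher from compound 2 to compound 4 (beyond the scatter), so the rise now holds on two cores, one with the fluoro group and one with the methyl group, and the two steps agree: the same change on two cores in this assay, a number 14.1 percentage points lower (beyond the scatter) from compound 1 to compound 3 and a number 14.1 percentage points lower (beyond the scatter) from compound 4 to compound 2, 0 percentage points apart, within the scatter of two such steps. With phenyl on that nitrogen, methyl in place of fluoro on the aromatic carbon gives a number 2.3 percentage points higher from compound 1 to compound 4 (within the scatter), and this step matches the one seen with hydrogen there: the same change on two cores in this assay, a number 2.3 percentage points lower (within the scatter) from compound 2 to compound 3 and a number 2.3 percentage points lower (within the scatter) from compound 4 to compound 1, 0 percentage points apart, within the scatter of two such steps. The compounds shown leave open whether a benzyl or an acetyl group on that nitrogen would give a similar rise.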